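Diethylamino in Place of Dimethylamino: One Change, One Expectation

A few compounds are considered here, and "the series" means these few. Any claim that something is new, unique, unknown or untested is made for them only; others in the source may bear on it.

Compound 1 `CN(C)c1ccc(C(=O)Nc2ccc(Oc3ncnc4ccsc34)cc2)cc1`: 50.8%
Compound 2 `c1cc(N2CCCC2)nc(Nc2ccc(Oc3ncnc4sccc34)cc2)n1`: 61%
Compound 3 `CN(c1ccc(Oc2ncnc3ccsc23)cc1)c1nccc(N2CCc3ccccc32)n1`: 58.2%

Of the compounds shown here, three share a common core and have been measured in a functional assay on A549 cells (Homo sapiens) for inhibition, read by MTT assay, with a stated time of 72 h, tested at 20 uM; on this read-out lower numbers stand for less inhibition and higher numbers for more inhibition at the one concentration tested (going by the name of the read-out). In this assay compound 1 gives 50.8%, the lowest of the three numbers. Its nearest neighbour is compound 3, whose 58.2% lies within the scatter of repeated measurements, so the two cannot be ordered. Compound 2, with 61%, stands beyond the scatter above compound 1.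

Compound 4 `CCN(CC)c1ccc(C(=O)Nc2ccc(Oc3ncnc4ccsc34)cc2)cc1` has not yet been measured in this assay. It differs from compound 1 in a single place: diethylamino in place of dimethylamino on an aromatic carbon. Among the compounds with values here, no measured pair in this set shows a change of this kind, so the size of the step has to be guessed. Compound 4 is expected to give about 54% in this assay, within a range from 38% to 70%. The step expected a number 3.2 percentage points higher from compound 1 to compound 4 (within the scatter) is small and is not expected to reach beyond the scatter in either direction.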

Compound 4, a percentage reported as inhibition, at one concentration (the size of the read-out at that concentration, not a potency): 63.8%
Estimate against measurement, compound 4: 9.8 percentage points below; measured number inside the range.
By their numbers in this assay, from the lowest: compounds 1, 3, 2 and 4 (each within the scatter of the next, the first and the last beyond it).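

Within the data shown here, until now no measured pair differed in one place, so nothing showed whether this position responds to a change at all. In this assay, putting diethylamino in place of dimethylamino on an aromatic carbon para to a large group gives a number 13 percentage points higher from compound 1 to compound 4 (beyond the scatter), a modest step that shows the read-out responds to this substituent alone, with no ring, net charge or hydrogen-bond donor entering. Nothing measured here bears on why the number moves.

A single pair cannot show whether the number would keep moving with a longer chain such as dipropylamino, or how a cyclic amine such as piperidine or morpholine would read at the same carbon. Going by these compounds, whether the step would hold at other concentrations or in other cell lines also stays open.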